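The source may hold more compounds than are shown below. What is called first, only, known or untested is meant among the compounds shown, and "the series" means these compounds.

Measured so far in a functional assay on the whole organism (Hindlimb, strain albino) with Mus musculus as the target, in the maximal electroshock model, with a stated time of 0.5 h; a lower number here means that less compound is needed, a higher number that more compound is needed for the effect:
- compound 1 `COc1ccc(/C=C/C(=O)Nc2nc3ccc([N+](=O)[O-])cc3s2)cc1` gives 315 umol/kg
- compound 2 `O=C(/C=C/c1ccc(Cl)cc1)Nc1nc2ccccc2s1` gives 367 umol/kg
- compound 3 `O=C(/C=C/c1ccc(Cl)cc1)Nc1nc2ccc(Cl)cc2s1` gives 204 umol/kg

Compound 3 stands at 204 umol/kg and lies within the scatter of both compound 1 and compound 2, so these numbers set no order among the three. Compound 4 `COc1ccc(/C=C/C(=O)Nc2nc3ccc(Cl)cc3s2)cc1` comes from compound 3 by a single change: methoxy in place of chloro on an aromatic carbon. This is methoxy in place of chloro on an aromatic carbon, para to a large group. Among the measured compounds shown here, no measured step covers this exchange. For the measured compounds named here, the one measured step, a 1.8-fold lower number from compound 2 to compound 3 (0.26 log units; within the scatter), is chloro in place of hydrogen at another place and bears on it only loosely. The methoxy group already occurs in compound 1 at 315 umol/kg, but that compound also differs on the core. No step beyond the scatter is therefore expected in this assay, and no direction can be firmly assigned. The expected change is small: a 1.2-fold higher number from compound 3 to compound 4 (0.09 log units; within the scatter). For compound 4 the estimated value is 250 umol/kg, with an expected range of 130 umol/kg to 450 umol/kg.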

Compound 4, dose for half-maximal effect: 259 umol/kg
Compound 4: middle estimate off by 1.0-fold (0.02 log units), on the low side; the range from low to high includes it.
By their numbers in this assay, from the lowest: compounds 3, 4, 1 and 2 (each within the scatter of the next).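

In (this assay), methoxy in place of chloro on an aromatic carbon, para to a large group, gives (a 1.3-fold higher number from compound 3 to compound 4 (0.10 log units; within the scatter)), so this exchange at this position produces no step beyond the scatter. With the methoxy group held fixed, chloro in place of nitro on an aromatic carbon gives (a 1.2-fold lower number from compound 1 to compound 4 (0.09 log units; within the scatter)), and this exchange also stays within the scatter. No available evidence bears on the reason for either result.

All single-place steps shown so far lie within the scatter, so the shown exchanges set no order among the compounds. Open, going by these compounds, is whether an amine, a carboxylic acid or a longer alkoxy chain in place of methoxy at this position would give a step beyond the scatter.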